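The source may hold more compounds than are shown below. What is called first, only, known or untested is meant among the compounds shown, and "the series" means these compounds.

Among the measured compounds shown here, compound 1 `Cc1c(Cl)ccc(S(=O)(=O)N(C)CCOCC(=O)N(C)Cc2ccc(C3=NCCN3)cc2)c1Cl` is one of two compounds measured in an assay on HEK293 cells for displacement of a labelled ligand from B1 bradykinin receptor (Homo sapiens), read by scintillation counting; on this read-out lower numbers stand for stronger inhibition and higher numbers for weaker inhibition; there compound 1 gives 2.1 nM, the lower of the two numbers. Compound 2 `COc1cc(C)c(S(=O)(=O)N(C)CCOCC(=O)N2CCN(CCN(C)C)CC2)c(C)c1` in this assay gives 106 nM, a value clearly weaker than that of compound 1. Compound 3 `CN(Cc1ccc(C2=NCCN2)cc1)C(=O)COCCN(C)S(=O)(=O)c1ccccc1C(F)(F)F` has not yet been measured; it differs from compound 1 by 2-(trifluoromethyl)phenyl in place of 2,4-dichloro-3-methylphenyl on a sulfonyl sulfur. For the measured compounds named here, no measured pair isolates this change, so the direction rests on expectation alone. A moderate loss is expected, and the step from compound 1 to compound 3 is estimated at a 7.1-fold higher number from compound 1 to compound 3 (0.85 log units; beyond the scatter). Compound 3 is thus expected to give about 15 nM, within a range of 4 nM to 60 nM.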

Compound 3, inhibition constant: 2.8 nM
Estimate against measurement, compound 3: 5.4-fold (0.73 log units) above; measured number below the stated range.
By their numbers in this assay, from the lowest: compounds 1 and 3 (each within the scatter of the next); then compound 2.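

In this assay, the exchange of 2,4-dichloro-3-methylphenyl for 2-(trifluoromethyl)phenyl on a sulfonyl sulfur gives a 1.3-fold higher number from compound 1 to compound 3 (0.12 log units; within the scatter). Among the compounds shown here, this is the first direct reading at this position, and it shows that these two substituted aryl groups cannot be told apart here when the rest of compound 1 is held constant. No available evidence explains this result. Going by these compounds, what a plain phenyl, a simple alkyl chain or an amine-bearing aryl group would do on the same sulfur remains open, as does whether this equivalence holds with other groups at the far end of the molecule.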